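Chloro additions on the N-aryl ring of the pyrrolidine acid

The source may report more compounds than this note shows. Statements on the series, on what has been measured and on what is new or still open speak of the compounds shown alone.

Compound 2 `O=C(O)C1CCN(c2ccccc2Cl)C1` gives 19000 nM in an assay on cells for inhibition of Palmitoleoyl-protein carboxylesterase NOTUM variant C330S (Homo sapiens), read by fluorescence, with a stated time of 40 min (on this read-out lower numbers stand for stronger inhibition and higher numbers for weaker inhibition), the highest number among the three measured compounds. Compound 1 `O=C(O)C1CCN(c2ccccc2F)C1` gives 11000 nM, and compound 3 `O=C(O)C1CCN(c2cccc(Cl)c2Cl)C1` gives 8000 nM. The step of a 1.7-fold higher number from compound 1 to compound 2 (0.24 log units; within the scatter) stays within the scatter, so compound 1 and compound 2 cannot be ordered. The step of a 2.4-fold lower number from compound 2 to compound 3 (0.38 log units; beyond the scatter) is beyond the scatter, a modest gain from a second chloro group.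

Compound 4 `O=C(O)C1CCN(c2cc(Cl)ccc2Cl)C1` differs from compound 2 by chloro in place of hydrogen on an aromatic carbon, on an aromatic carbon of a six-membered aromatic ring of carbon only, meta to a group of 8 heavy atoms and para to a chloro group. Going by the values given here, the only measured step of the same kind is the one from compound 2 to compound 3, where the chloro entered elsewhere on the ring; no step tests this position. A lowering of the number in this assay is therefore expected, but of uncertain size.

For compound 4 the estimate is 10000 nM, with a range from 4000 nM to 25000 nM. This estimate means a step of a 1.9-fold lower number from compound 2 to compound 4 (0.28 log units; within the scatter) that is expected to be at most modest.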

Compound 4, half-maximal inhibitory concentration: 7900 nM
Compound 4: the middle estimate sits 1.3-fold (0.10 log units) above what was measured, within the range that was stated.
By their numbers in this assay, from the lowest: compounds 4, 3, 1 and 2 (each within the scatter of the next, the first and the last beyond it).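

The chloro placed para to a chloro group gives a 2.4-fold lower number from compound 2 to compound 4 (0.38 log units; beyond the scatter) in this assay, so this position also takes a second chloro with a modest gain. The size matches a 2.4-fold lower number from compound 2 to compound 3 (0.38 log units; beyond the scatter), and compound 3 at 8000 nM and compound 4 at 7900 nM lie within the scatter of each other, so these two placements of the second chloro cannot be ordered. Nothing at hand gives a reason for the gain at either place.

Open, going by these compounds, is whether a group other than chloro at this position, such as methoxy, nitrile or an amine, keeps the gain. Also open, on these data alone, is whether the gain survives when the carboxylic acid of the shared core gives way to an amide.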